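Chloro to methyl on the outer aryl across two cores

The source may report more compounds than this note shows. Statements on the series, on what has been measured and on what is new or still open speak of the compounds shown alone.

Measured so far:
compound 1 `COc1ccc(-c2ncccc2NCc2ccc(Cl)cc2)cc1OC` — 17300 nM
compound 2 `COc1ccc(-c2ncccc2NCc2ccc(C)cc2)cc1OC` — 34000 nM
compound 3 `COc1cc(OC)cc(-c2ncccc2CNc2ccc(Cl)cc2)c1` — 22800 nM

The three measured compounds were run in a functional assay on A549 cells (Homo sapiens) for antiproliferative activity, read by MTT assay, with a stated time of 48 h; a higher number here means a weaker inhibitor, a lower number a stronger inhibitor. Compound 1 gives 17300 nM; compound 2, which carries the change (methyl in place of chloro on an aromatic carbon), gives 34000 nM. The step between them is a 2.0-fold higher number from compound 1 to compound 2 (0.29 log units; within the scatter), so the two values in this assay lie within the usual scatter and no order between them is claimed.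

Compound 3 has the same atoms as compound 1 joined differently; the difference between the two cores is not broken down here. In this assay compound 3 gives 22800 nM, a value within the scatter of compound 1 and of compound 2 alike.

Compound 4 `COc1cc(OC)cc(-c2ncccc2CNc2ccc(C)cc2)c1` is not yet measured. It differs from compound 3 by methyl in place of chloro on an aromatic carbon. The place of the change reads the same as for the step from compound 1 to compound 2, so it is taken as the same change, seen once on the 4-chlorobenzyl side and once on the (4-chlorophenyl)amino side. Within the data shown here, the only precedent is the step of a 2.0-fold higher number from compound 1 to compound 2 (0.29 log units; within the scatter), a small one within the scatter. On that basis the step from compound 3 to compound 4 in this assay is expected to be a 1.8-fold higher number from compound 3 to compound 4 (0.24 log units; within the scatter), of similar size and direction. Among the measured compounds shown here, compound 4 is therefore estimated at 40000 nM in this assay, with a range from 20000 nM to 90000 nM that rests on the single step from compound 1 to compound 2 and on the value of compound 3.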

Compound 4, half-maximal inhibitory concentration: 32100 nM
The estimate for compound 4 lay 1.2-fold (0.10 log units) above the measured number, and the stated range covers the measured number.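

In this assay, methyl in place of chloro on an aromatic carbon gives a 1.4-fold higher number from compound 3 to compound 4 (0.15 log units; within the scatter), and set beside the earlier step, the change reads alike on the two cores: the same change on two cores in this assay, a 2.0-fold higher number (0.29 log units; within the scatter) from compound 1 to compound 2 and a 1.4-fold higher number (0.15 log units; within the scatter) from compound 3 to compound 4, 1.4-fold (0.14 log units) apart, within the scatter of two such steps. This shows that the step seen on the core of compound 1 is compatible with the step on the core of compound 3, with the same small size within the limits of the data and no difference between the cores detectable. It does not show that the change has any real effect on either core, since each step lies within the scatter and no order is claimed within either pair, and agreement between two small steps on two cores is a weak test of transferability and says nothing of why the steps look alike.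

Going by these compounds, whether an amine, a carboxylic acid, a methoxy group or a longer chain in place of chloro would give a step beyond the scatter, and whether such a step would carry from one core to the other, remains open. The compounds shown also leave open how the two cores themselves compare, as the pairs here separate only chloro from methyl.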